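A few compounds are considered here, and "the series" means these few. Any claim that something is new, unique, unknown or untested is made for them only; others in the source may bear on it.

Of the compounds shown here, two built on the shared core have been measured in a functional assay on KB cells (Homo sapiens) for cytotoxicity; on this read-out higher numbers stand for an effect only at larger amounts of compound and lower numbers for an effect already at smaller amounts. Compound 1 `CCC[C@@H](OC(C)=O)C1=C(Br)C(=C(Br)Br)OC1=O` carries an acetyl on an oxygen on a saturated carbon, and in this assay compound 1 gives 0.3 ug/mL. Compound 2 `CCC[C@@H](O)C1=C(Br)C(=C(Br)Br)OC1=O` has hydrogen in place of that acetyl, and in this assay compound 2 gives 0.5 ug/mL. The step of a 1.7-fold higher number from compound 1 to compound 2 (0.22 log units; within the scatter) shows that this exchange hardly moved the number, so the two values are indistinguishable within the usual scatter of the method. Going by the values given here, compound 2 thus stands on a level with the only other compound measured.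

Compound 3 `CCCCC1=C(Br)C(=C(Br)Br)OC1=O` goes one step further: hydrogen in place of hydroxy on a saturated chain carbon bound to a double-bonded ring carbon and a saturated chain carbon. Among the compounds with values here, no measured step covers the loss of a hydroxy; the only step known, a 1.7-fold higher number from compound 1 to compound 2 (0.22 log units; within the scatter), concerns the same oxygen and stayed within the scatter. On that basis the step of no change at the digits printed from compound 2 to compound 3 (within the scatter) is expected to be small, with no clear direction. In this assay compound 3 is therefore estimated at 0.5 ug/mL, with a range from 0.2 ug/mL to 1.5 ug/mL.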

Compound 3, concentration for half-maximal effect: > 20 ug/mL
Compound 3: a limit, no number; the forecaster's own chance of this, stated with the estimate: 5%; at least 40-fold (1.60 log units) between middle value and limit.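

Compound 1 and compound 2 differ only in what sits on the oxygen, and that exchange left open whether the oxygen itself matters at this saturated chain carbon. The change from 1-hydroxybutyl to butyl answers this for the shared core: losing the oxygen altogether gives an at least 40-fold higher number from compound 2 to compound 3 (1.60 log units; beyond the scatter) in this assay, and replacing the whole acetoxy by hydrogen gives an at least 66-fold higher number from compound 1 to compound 3 (1.82 log units; beyond the scatter), so the effect at small amounts is seen here with hydroxy or acetoxy on this carbon and is lost with hydrogen, even though swapping acetyl for hydrogen on the oxygen made little difference. The value of compound 3 is a limit and not a number, so the true size of both steps stays unknown: the limit of > 20 ug/mL in this assay, at which 1 of the 3 values shown sits.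

The three compounds cannot tell whether the oxygen is needed as such or whether another group on this carbon, such as an amine, a methoxy or a fluorine, would keep the effect. They also leave open how the effect responds to a longer chain in place of the propyl end of the 1-hydroxybutyl group, and why the loss of the hydroxy has so large a consequence.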